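A few compounds are considered here, and "the series" means these few. Any claim that something is new, unique, unknown or untested is made for them only; others in the source may bear on it.

Compound 2 `COc1cc(Cl)cc(-c2nn(-c3cccc(NC(=O)c4cccc(C(F)(F)F)c4)c3)cc2-c2ccncc2)c1` and compound 1 `COc1cc(Cl)cc(-c2nn(-c3cccc(NC(=O)c4ccc(Cl)c(Cl)c4)c3)cc2-c2ccncc2)c1` share one core and differ only in the aryl group on the amide carbonyl. In a functional assay on MOLT-4 cells (Homo sapiens) for inhibition, read by sulforhodamine B assay, with a stated time of 48 h, tested at 10 uM (a higher number here means a weaker effect of the compound at the concentration tested, a lower number a stronger effect), compound 1 gives 54.9%, whereas compound 2 gives 29%. Within the data shown here, that change, a number 25.9 percentage points lower from compound 1 to compound 2 (beyond the scatter), is the only step measured so far, and it leaves compound 2 with the lower of the two numbers.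

Compound 3 `COc1cc(Cl)cc(-c2nn(-c3cccc(NC(=O)c4cc(C(F)(F)F)cc(C(F)(F)F)c4)c3)cc2-c2ccncc2)c1` takes the next step from compound 2: trifluoromethyl in place of hydrogen on an aromatic carbon. The second trifluoromethyl thus sits on the same aryl group that was altered between compound 1 and compound 2. The earlier step bears on compound 3 only loosely, since it exchanged one whole aryl group for another rather than adding a group; it showed that this position of the molecule can move the read-out by a modest amount. Among the measured compounds shown here, no measured step tells how a second trifluoromethyl on that ring acts.

Compound 3 is therefore expected to stay near compound 2, with a step of a number 2 percentage points lower from compound 2 to compound 3 (within the scatter) that need not exceed the scatter. In this assay the value of compound 3 is estimated at 27%, between 10% and 48%.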

Compound 3, a percentage reported as activity, at one concentration (the size of the read-out at that concentration, not a potency): 55.3%
Beside the measured number, compound 3's estimate is 28.3 percentage points below it; the measured number lies above the stated range.
By their numbers in this assay, from the lowest: compound 2; then compounds 1 and 3 (each within the scatter of the next).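

The aryl group on the amide carbonyl proves sensitive to a single added group: placing a second trifluoromethyl on an aromatic carbon, meta to a trifluoromethyl group, gives in this assay a number 26.3 percentage points higher from compound 2 to compound 3 (beyond the scatter), so the effect at the concentration tested is weaker. The earlier step exchanged one whole aryl group for another, whereas this one shows that the gain seen with compound 2 is lost when the same ring gains one more group, so more trifluoromethyl on this ring does not go with a stronger effect here: compound 2 keeps the lowest number of the three, while compound 1 at 54.9% and compound 3 at 55.3% lie within the scatter of each other. Nothing shown on these compounds accounts for this reversal.

The compounds shown leave open whether the loss belongs to trifluoromethyl itself or would follow any group on that carbon, such as an amine, a nitrile or a carboxylic acid. They also leave open whether the same step would give a similar change on another aryl group or in other cells.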